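A few compounds are considered here, and "the series" means these few. Any claim that something is new, unique, unknown or untested is made for them only; others in the source may bear on it.

Compound 1, `CC(C)(C)c1cc(CCC(=O)NC2CCN(Cc3ccccc3)CC2)cc(C(C)(C)C)c1O`: in an assay on isolated protein for inhibition of Amine oxidase [flavin-containing] A (Homo sapiens), read by fluorescence, with stated times of 15 min and 20 min (on this read-out higher numbers stand for weaker inhibition and lower numbers for stronger inhibition), compound 1 gives 90200 nM.
Compound 2, `CC(C)(C)c1cc(CCC(=O)NCCC2CCN(Cc3ccccc3)CC2)cc(C(C)(C)C)c1O`: in this assay compound 2 gives 94100 nM.
Compound 3, `CC(C)(C)c1cc(/C=C/C(=O)NCCC2CCN(Cc3cccc(F)c3)CC2)cc(C(C)(C)C)c1O`: in this assay compound 3 gives 58400 nM.

All three compounds share the same core and all three sit at the weak end of what this assay can register. Compound 3 carries the lowest number of the three, but its gaps to compound 1 and to compound 2 both fall within the usual scatter of repeated measurements, so the three values cannot be told apart with any confidence.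

Compound 4, `CC(C)(C)c1cc(/C=C/C(=O)NCCC2CCN(Cc3ccc(C#N)cc3)CC2)cc(C(C)(C)C)c1O`, is the next compound and has not yet been measured. It differs from compound 3 in one place: 4-cyanophenyl in place of 3-fluorophenyl on a saturated chain carbon bound to an amine nitrogen in a ring. Among the measured compounds there is no pair that differs only in this way, so there is no measured step to lean on. Within the data shown here, with no precedent for this change, and with the three measured values lying so close together, the expectation is that compound 4 will behave much like compound 3, and the step of a 1.0-fold higher number from compound 3 to compound 4 (0.01 log units; within the scatter) is expected to stay within the scatter. On that basis compound 4 is estimated to give about 60000 nM in this assay, with a likely range from 25000 nM to 150000 nM.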

Compound 4, half-maximal inhibitory concentration: 78200 nM
The estimate for compound 4 lay 1.3-fold (0.12 log units) below the measured number; the range from low to high includes it.
By their numbers in this assay, from the lowest: compounds 3, 4, 1 and 2 (each within the scatter of the next).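

Among these compounds, replacing 3-fluorobenzyl with 4-cyanobenzyl gives the first measured comparison at this position: in this assay, the result is a 1.3-fold higher number from compound 3 to compound 4 (0.13 log units; within the scatter). The two compounds therefore cannot be told apart, which shows that on this shared core, the 3-fluorophenyl group can give way to a 4-cyanophenyl group, with its nitrile and a hydrogen-bond acceptor, without a change that this measurement can separate from ordinary scatter. This one pair alters both the group on the ring and its place there, so it cannot show what either alteration would do alone, and nothing available explains the result.

On these data alone, whether this position is generally tolerant or the two groups simply happen to give similar numbers remains open, since a single step within the scatter cannot distinguish between those possibilities. As far as these compounds go, it also remains open whether a carboxylic acid or an amine on this ring, or a longer chain between the ring and the amine nitrogen, would move the number beyond the scatter in either direction.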